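The source may report more compounds than this note shows. Statements on the series, on what has been measured and on what is new or still open speak of the compounds shown alone.

Measured in an ADME assay on HEp-2 cells (Homo sapiens) for cytotoxicity; a higher number here means that more compound is tolerated, a lower number that less compound is tolerated:
- compound 1 `C=C(C)n1c(=O)n(Cc2nc3cc(C#N)ccc3n2CCC(C)C)c2ccccc21` gives 1480 nM
- compound 2 `C=C(C)n1c(=O)n(Cc2nc3cc(C(C)=O)ccc3n2CCC(C)C)c2ccccc21` gives 740 nM

Within the data shown here, compound 2 stands level with compound 1, as the only measured step shows: a 2.0-fold lower number from compound 1 to compound 2 (0.30 log units; within the scatter). That step put acetyl in place of cyano on an aromatic carbon.

Compound 3 `C=C(C)n1c(=O)n(Cc2nc3cc(C(=O)O)ccc3n2CCC(C)C)c2ccccc21` keeps the shared core and turns that acetyl into carboxy: hydroxy in place of methyl on a carbonyl carbon. Put simply, it has hydroxy in place of methyl on a carbonyl carbon.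

The earlier step bears on this change only loosely. Among the measured compounds shown here, it altered the same substituent, but no measured compound carries a carboxy group, so there is no direct guide. That step also brought in no hydrogen-bond donor, whereas this change does, so its small size may not carry over. Starting from compound 2 at 740 nM, the expectation in this assay is tentative: more compound tolerated, by a step beyond the scatter. The expected step is a 6.8-fold higher number from compound 2 to compound 3 (0.83 log units; beyond the scatter). Compound 3 is estimated at 5000 nM, with an expected range of 1000 nM to 40000 nM.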

Compound 3, half-maximal cytotoxic concentration: 30000 nM
Estimate against measurement, compound 3: 6.0-fold (0.78 log units) below, within the range that was stated.
By their numbers in this assay, from the lowest: compounds 2 and 1 (each within the scatter of the next); then compound 3.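

In this assay hydroxy in place of methyl on the carbonyl carbon brings a 41-fold higher number from compound 2 to compound 3 (1.61 log units; beyond the scatter) while carboxy in place of cyano on the aromatic carbon brings a 20-fold higher number from compound 1 to compound 3 (1.31 log units; beyond the scatter) at the same place. Compound 1 and compound 2 sit within the scatter of each other, so nitrile and acetyl alone gave no sign that this aromatic carbon matters in this measure, but carboxy now sets compound 3 well apart from both, with more compound tolerated. The swap exchanges just one heavy atom and adds a hydrogen-bond donor that methyl lacks, yet nothing measured here links the large step to that donor or to any other feature of the group.

The compounds shown leave open whether the hydroxy alone carries the step or needs the carbonyl it sits on, and a methyl ester or a carboxamide on that carbonyl carbon would help to separate the two. Also open, as far as these compounds go, is whether a carboxylic acid on a longer chain, such as carboxymethyl on the aromatic carbon, would read like compound 3.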